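Dichlorophenyl in place of dimethylphenyl on the triazole

The compounds below may be only part of what the source reports. "The series", "measured", "known", "first", "only" and "open" are said of these compounds alone.

Compound 3 `Cc1ccc(-n2nncc2CN2C(=O)C3(C(C#N)=C(N)Oc4c(N)cc5nc6ccccc6nc5c43)c3ccccc32)cc1C` sits at the edge of what a functional assay on HCT-116 cells (Homo sapiens) for antiproliferative activity, read by MTT assay, with a stated time of 48 h (on this read-out higher numbers stand for weaker inhibition and lower numbers for stronger inhibition), reports: in this assay compound 3 gives > 50000 nM, a limit and not a number. Compound 2 `COc1ccc(-n2nncc2CN2C(=O)C3(C(C#N)=C(N)Oc4c(N)cc5nc6ccccc6nc5c43)c3ccccc32)cc1` likewise gives > 50000 nM in this assay, also a limit. Only compound 1 `CCc1ccccc1-n1nncc1CN1C(=O)C2(C(C#N)=C(N)Oc3c(N)cc4nc5ccccc5nc4c32)c2ccccc21` gives a number, 10300 nM in this assay. The steps from the 2-ethylphenyl compound read an at least 4.8-fold higher number from compound 1 to compound 2 (0.68 log units; beyond the scatter) and an at least 4.8-fold higher number from compound 1 to compound 3 (0.68 log units; beyond the scatter), while the step between the two limited compounds is a step that the two limits leave unreadable from compound 2 to compound 3; the limit of > 50000 nM in this assay, at which 2 of the 3 values shown sit, is where two of the three values rest.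

Compound 4 `N#CC1=C(N)Oc2c(N)cc3nc4ccccc4nc3c2C12C(=O)N(Cc1cnnn1-c1ccc(Cl)cc1Cl)c1ccccc12` differs from compound 3 by 2,4-dichlorophenyl in place of 3,4-dimethylphenyl on an aromatic nitrogen. Within the data shown here, no measured step covers a dichlorophenyl group, and since compound 3 is itself a limit, the size of the step of an at least 1.4-fold lower number from compound 3 to compound 4 (0.15 log units; that floor lies within the scatter) that the estimate implies cannot be checked against a number. With a 2-ethylphenyl compound at a modest number and two other aryl groups past the limit, compound 4 is expected at 35000 nM, within 9000 nM to 120000 nM in this assay.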

Compound 4, half-maximal inhibitory concentration: > 50000 nM
Compound 4 was reported as a limit; the forecaster's own chance of this, stated with the estimate: 50%; middle value at least 1.4-fold (0.15 log units) from the limit.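

In this assay compound 4 gives > 50000 nM, a limit and not a number, so a phenyl ring carrying two chlorines joins 4-methoxyphenyl and 3,4-dimethylphenyl at this limit on the aromatic nitrogen. Putting 2,4-dichlorophenyl in place of 2-ethylphenyl gives an at least 4.8-fold higher number from compound 1 to compound 4 (0.68 log units; beyond the scatter), which leaves compound 1 as the only one of the four with a measured number, while the steps to compound 4 from compound 2 and compound 3 join two limits and cannot be read. The limit now holds most of the compounds shown: the limit of > 50000 nM in this assay, at which 3 of the 4 values shown sit.

On these data alone, it remains open whether a 2-methylphenyl, 2-chlorophenyl or unsubstituted phenyl group on this nitrogen would give a number. As far as these compounds go, how far compound 2, compound 3 and compound 4 lie past their limits, and whether they differ from one another, also stays open.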